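A few compounds are considered here, and "the series" means these few. Any claim that something is new, unique, unknown or untested is made for them only; others in the source may bear on it.

Compound 1, with the structure `COc1ccc(C2=NN(C3=NC(=O)/C(=C4\C(=O)Nc5ccc(Br)cc54)S3)C(c3ccc(Cl)cc3)C2)cc1`, gives 340 nM in a functional assay on cells (Melanoma cell, Homo sapiens) for cytotoxicity, read by sulforhodamine B assay, with a stated time of 48 h; a higher number here means a weaker inhibitor of growth, a lower number a stronger inhibitor of growth.
Compound 2, with the structure `COc1ccc(C2=NN(C3=NC(=O)/C(=C4\C(=O)Nc5ccc(Cl)cc54)S3)C(c3ccc(Cl)cc3)C2)cc1`, gives 440 nM in this assay.
Compound 3, with the structure `COc1ccc(-c2cc(-c3ccc(Cl)cc3)n(C3C(=O)Nc4ccc(Br)cc43)n2)cc1`, gives 49300 nM in this assay.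

Compound 1 and compound 2 share one core and differ in a single place: chloro in place of bromo on an aromatic carbon. This change made a 1.3-fold higher number from compound 1 to compound 2 (0.11 log units; within the scatter), so the two values cannot be told apart.

Compound 3 is built on a different core, and its values stand far from those of compound 1 and compound 2 in this assay. The difference between the two cores is not broken down here.

Compound 4, with the structure `COc1ccc(-c2cc(-c3ccc(Cl)cc3)n(C3C(=O)Nc4ccc(Cl)cc43)n2)cc1`, has not been measured. It stands to compound 3 exactly as compound 2 stands to compound 1: chloro in place of bromo on an aromatic carbon. The place is the same in both pairs, so this is the same change, seen a second time.

Because the same change gave a 1.3-fold higher number from compound 1 to compound 2 (0.11 log units; within the scatter), the step expected here is a 1.2-fold higher number from compound 3 to compound 4 (0.09 log units; within the scatter), beside the earlier one. Compound 4 is expected at about 60000 nM in this assay, most likely between 30000 nM and 120000 nM.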

Compound 4, concentration for total growth inhibition: 46700 nM
Compound 4: middle estimate off by 1.3-fold (0.11 log units), on the high side; the range from low to high includes it.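

Replacing bromo with chloro on the second core gave a 1.1-fold lower number from compound 3 to compound 4 (0.02 log units; within the scatter) in this assay, so these two values cannot be told apart. The same swap also left no readable change on the first core, and the two steps agree with each other: the same change on two cores in this assay, a 1.3-fold higher number (0.11 log units; within the scatter) from compound 1 to compound 2 and a 1.1-fold lower number (0.02 log units; within the scatter) from compound 3 to compound 4, 1.4-fold (0.14 log units) apart, within the scatter of two such steps

This shows that, for these two cores in this one assay, the swap can be carried from one core to the other and still leave the number within the scatter, but it does not show that the same would hold on a further core or in a different assay, and two pairs are too few to make a general rule.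

Only bromo and chloro appear at this place on the aromatic ring, so the compounds shown leave open what a fluoro group, an amine or a carboxylic acid there would do to the number. The methoxy group is also the same in all four compounds, which leaves open what a longer chain in its place would do.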